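A ring swap starting from a compound without a number

The source may report more compounds than this note shows. Statements on the series, on what has been measured and on what is new or still open speak of the compounds shown alone.

Results in a functional assay on HCT-116 cells (Homo sapiens) for inhibition; a higher number here means a weaker inhibitor, a lower number a stronger inhibitor:
Compound 1 `CCNC(=O)c1noc(-c2cc(C(C)C)c(O)cc2O)c1-c1cc(CNC)no1`: 164 nM
Compound 2 `CCNC(=O)c1noc(-c2cc(C(C)C)c(O)cc2O)c1-c1cc(CNC(C)=O)no1`: 167 nM
Compound 3 `CCNC(=O)c1noc(-c2cc(C(C)C)c(O)cc2O)c1-c1cc(C(=O)OCC)no1`: "not determined" (no result reported)

Compound 3 has no standing on these numbers, as no result was reported for it. Compound 4 `CCNC(=O)c1noc(-c2cc(C(C)C)c(O)cc2O)c1-c1ccn(CC)n1` carries 1-ethyl-1H-pyrazol-3-yl in place of 3-(ethoxycarbonyl)-1,2-oxazol-5-yl on an aromatic carbon. Among the compounds with values here, the one measured step, a 1.0-fold higher number from compound 1 to compound 2 (0.01 log units; within the scatter), is acetyl in place of methyl on an amine nitrogen, a far smaller change. It only hints that this part of the molecule may tolerate change. With no starting number, no step size or direction can be expected in this assay, so the expectation rests on compound 1 at 164 nM and compound 2 at 167 nM. Compound 4 is estimated at 200 nM, with an expected range of 60 nM to 700 nM.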

Compound 4, half-maximal inhibitory concentration: 25 nM
For compound 4 the middle estimate is 8.0-fold (0.90 log units) above the measured one; measured number below the stated range.
By their numbers in this assay, from the lowest: compound 4; then compounds 1 and 2 (each within the scatter of the next).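

In this assay, putting 1-ethyl-1H-pyrazol-3-yl in place of the substituted 1,2-oxazol-5-yl groups gives a 6.7-fold lower number from compound 2 to compound 4 (0.82 log units; beyond the scatter) and a 6.6-fold lower number from compound 1 to compound 4 (0.82 log units; beyond the scatter). So this position responds to a change of the whole ring group, which the swap on the side-chain amine nitrogen between compounds 1 and 2 did not show. The step from compound 3 cannot be read, as it has no number, and no evidence at hand explains the change.

Still open, from the compounds shown here alone, is which part of the new group matters: whether the ethyl itself counts, and whether a 1-methyl group, a longer chain or an amine in its place would keep this level of inhibition.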